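This account rests on a few compounds, and the source may have more. Where it says the series, first, only, none or still open, it means among the compounds named here.

In an ADME assay on a cell-free system (plasma, Homo sapiens) for metabolic stability, read by LC-MS; on this read-out lower numbers stand for a shorter-lived compound and higher numbers for a longer-lived compound:

- compound 1 `NCc1ccc(C(=O)Nc2ccncc2F)cc1-c1cccc(C(=O)Nc2cccc(CC(=O)O)c2)c1`: > 2 h, a limit
- compound 2 `COC(=O)c1cccc(NC(=O)c2cccc(-c3cc(C(=O)Nc4ccncc4F)ccc3CN)c2)c1F`: < 0.0834 h, a limit
- compound 3 `CCC(C)OC(=O)c1cccc(NC(=O)c2cccc(-c3cc(C(=O)Nc4ccncc4F)ccc3CN)c2)c1`: 0.267 h
- compound 4 `NCc1ccc(C(=O)Nc2ccncc2F)cc1-c1cccc(C(=O)Nc2ccccc2)c1`: not yet measured

Among the compounds with values here, compound 3 gives the only number here; the other two values are limits. Compound 4 carries hydrogen in place of sec-butoxycarbonyl on an aromatic carbon. Within the data shown here, two measured steps bear on this: an at least 7.4-fold lower number from compound 1 to compound 3 (0.87 log units; beyond the scatter) and an at least 23-fold lower number from compound 1 to compound 2 (1.37 log units; beyond the scatter). Both lie beyond the scatter, the first at least modest and the second large. Among the measured compounds shown here, both end on a compound with an alkoxycarbonyl group, which compound 4 lacks, though no measured compound has hydrogen at this place. A clear rise in this assay is therefore expected, of at least modest size. The expected change is a 7.5-fold higher number from compound 3 to compound 4 (0.87 log units; beyond the scatter). The estimate for compound 4 is 2 h, with an expected range of 0.7 h to 6 h.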

Compound 4, half-life: > 2 h
Compound 4: a limit, no number; the forecaster's own chance of this, stated with the estimate: 55%; the middle value lies on the limit itself.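

In this assay, within the data shown here, compound 4 gives the first comparison with hydrogen at this place: hydrogen in place of sec-butoxycarbonyl gives an at least 7.4-fold higher number from compound 3 to compound 4 (0.87 log units; beyond the scatter), and phenyl in place of 2-fluoro-3-(methoxycarbonyl)phenyl gives an at least 23-fold higher number from compound 2 to compound 4 (1.37 log units; beyond the scatter). The short half-lives of compound 2 and compound 3 thus stand out against the unsubstituted phenyl as well as against the carboxymethyl group of compound 1. A long half-life in this series therefore does not require the carboxymethyl group.

On these data alone, the step between compound 1 and compound 4 cannot be read, because both values are limits: the limit of > 2 h in this assay, at which 2 of the 4 values shown sit. What a primary amide or a carboxylic acid set directly on this ring would give remains open.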